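Swapping the side group on a shared oxadiazole-bearing core

This account rests on a few compounds, and the source may have more. Where it says the series, first, only, none or still open, it means among the compounds named here.

Measured compounds, all in a functional assay on HCT-116 cells (Homo sapiens) for cytotoxicity, read by MTT assay, with a stated time of 72 h; on this read-out higher numbers stand for weaker inhibition and lower numbers for stronger inhibition:
Compound 1 `CN1CCN(Cc2nnc(-c3cc(S(N)(=O)=O)c(SCc4ccccc4)cc3Cl)o2)CC1` gives 75000 nM.
Compound 2 `NS(=O)(=O)c1cc(-c2nnc(CN3CCN(c4ccccc4)CC3)o2)c(Cl)cc1SCc1ccccc1` gives 105000 nM.
Compound 3 `NS(=O)(=O)c1cc(-c2nnc(Cn3cc(-c4ccccc4)nn3)o2)c(Cl)cc1SCc1ccccc1` gives 75000 nM.

All three compounds share one core and differ only in the group attached to a saturated chain carbon bound to an aromatic carbon. Compound 3 is level with compound 1 at the digits shown, the two together the lowest of the three numbers; the remaining gap is a 1.4-fold lower number from compound 2 to compound 3 (0.15 log units; within the scatter), so compound 3 is not set apart from either neighbour.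

Compound 4 `NS(=O)(=O)c1cc(-c2nnc(CNC(=O)c3ccccc3)o2)c(Cl)cc1SCc1ccccc1` carries the change (benzamido in place of 4-phenyl-1H-1,2,3-triazol-1-yl on a saturated chain carbon bound to an aromatic carbon). Two earlier steps at the same place are informative: no change at the digits printed from compound 1 to compound 3 (within the scatter) and a 1.4-fold lower number from compound 2 to compound 3 (0.15 log units; within the scatter). Neither moved the read-out beyond the scatter, and the step of a 1.4-fold higher number from compound 1 to compound 2 (0.15 log units; within the scatter), at a nearby spot, was likewise flat. Three different groups at this position have left the number essentially where it was. For the measured compounds named here, the incoming benzamido group brings a hydrogen-bond donor that none of the measured groups has, so the data give no direct precedent, but nothing in them points to a shift in either direction.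

The expected step is therefore a 1.1-fold higher number from compound 3 to compound 4 (0.03 log units; within the scatter), no change beyond the scatter. Compound 4 is estimated at 80000 nM, with a likely range from 30000 nM to 200000 nM.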

Compound 4, half-maximal inhibitory concentration: 42000 nM
The estimate for compound 4 lay 1.9-fold (0.28 log units) above the measured number, and the stated range covers the measured number.
By their numbers in this assay, from the lowest: compounds 4, 1, 3 and 2 (each within the scatter of the next, the first and the last beyond it).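

In this assay, for the compounds shown here, the step of a 2.5-fold lower number from compound 2 to compound 4 (0.40 log units; beyond the scatter) is the first at this place, on a saturated chain carbon bound to an aromatic carbon, to pass beyond the scatter, so the read-out here is not wholly insensitive to the group attached, though the step is modest. The other two new steps, a 1.8-fold lower number from compound 3 to compound 4 (0.25 log units; within the scatter) and a 1.8-fold lower number from compound 1 to compound 4 (0.25 log units; within the scatter), stay within the scatter, which means that benzamido is separated only from 4-phenylpiperazin-1-yl and not from 4-phenyl-1H-1,2,3-triazol-1-yl or 4-methylpiperazin-1-yl. Going by these compounds alone, no measurement offered here accounts for the one step that passes the scatter.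

The compounds shown leave open which part of benzamido goes with the step from compound 2, whether the amide hydrogen, the carbonyl or the phenyl ring. N-methylbenzamido, with a methyl group in place of the amide hydrogen, and acetamido, with a methyl group in place of the phenyl ring, would each change one of these parts on the shared core and could begin to tell them apart.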